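Pyrrole-benzothiazole series: fluoro for methyl, second pair

This account rests on a few compounds, and the source may have more. Where it says the series, first, only, none or still open, it means among the compounds named here.

Measured compounds:
compound 1, `Cc1ccc(-c2ccc(C)n2-c2ccc(-c3nc4ccccc4s3)cc2)cc1`: 4400 nM
compound 2, `Cc1ccc(-c2ccc(F)cc2)n1-c1ccc(-c2nc3ccccc3s2)cc1`: 4340 nM
compound 3, `Cc1ccc(-c2ccc(C)n2-c2ccc(-c3nc4ccc(F)cc4s3)cc2)cc1`: 3140 nM

In a functional assay on MDA-MB-231 cells (Homo sapiens) for cytotoxicity, read by sulforhodamine B assay, with a stated time of 48 h (a higher number here means a weaker inhibitor of growth, a lower number a stronger inhibitor of growth), compound 1 gives 4400 nM, compound 2 gives 4340 nM and compound 3 gives 3140 nM. All three values lie within the scatter of one another, so no order among them is claimed. The core of compound 3 differs from that of compound 1 by fluoro in place of hydrogen on an aromatic carbon; the step of a 1.4-fold lower number from compound 1 to compound 3 (0.15 log units; within the scatter) is within the scatter.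

Compound 2 arises from compound 1 by fluoro in place of methyl on an aromatic carbon, the 4-methylphenyl becoming 4-fluorophenyl. The step of a 1.0-fold lower number from compound 1 to compound 2 (0.01 log units; within the scatter) is within the scatter. The same change occurs twice here: compound 4, `Cc1ccc(-c2ccc(F)cc2)n1-c1ccc(-c2nc3ccc(F)cc3s2)cc1`, not yet measured in this assay, arises from compound 3 by fluoro in place of methyl on an aromatic carbon, at a place described in the same words.

Because a 1.0-fold lower number from compound 1 to compound 2 (0.01 log units; within the scatter) was within the scatter, the expected step is of about the same size, a 1.0-fold lower number from compound 3 to compound 4 (0.01 log units; within the scatter). For compound 4 the estimate in this assay is 3100 nM, expected to fall between 1600 nM and 6200 nM.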

Compound 4, concentration for 50% growth inhibition: 3030 nM
The estimate for compound 4 lay 1.0-fold (0.01 log units) above the measured number; low and high end bracket the measured number.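

In this assay, fluoro in place of methyl on an aromatic carbon, the 4-methylphenyl becoming 4-fluorophenyl, gives a 1.0-fold lower number from compound 3 to compound 4 (0.02 log units; within the scatter), and this agrees with the step on the other core: the same change on two cores in this assay, a 1.0-fold lower number (0.01 log units; within the scatter) from compound 1 to compound 2 and a 1.0-fold lower number (0.02 log units; within the scatter) from compound 3 to compound 4, 1.0-fold (0.01 log units) apart, within the scatter of two such steps. Fluoro in place of hydrogen on an aromatic carbon gives a 1.4-fold lower number from compound 2 to compound 4 (0.16 log units; within the scatter), which likewise agrees with its earlier counterpart: the same change on two cores in this assay, a 1.4-fold lower number (0.15 log units; within the scatter) from compound 1 to compound 3 and a 1.4-fold lower number (0.16 log units; within the scatter) from compound 2 to compound 4, 1.0-fold (0.01 log units) apart, within the scatter of two such steps. Each change therefore looks the same on both cores, but all four compounds lie within the scatter of one another, so this agreement is a weak test of transfer and shows nothing about how a change with a step beyond the scatter would carry from one core to another.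

Still open, on these data alone, is whether any group at the place of the methyl or fluoro, such as an amine, a carboxylic acid or a longer chain, would give a step beyond the scatter. As far as these compounds go, whether the agreement between steps extends to other cores or to another cell line also remains open.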